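This account rests on a few compounds, and the source may have more. Where it says the series, first, only, none or still open, it means among the compounds named here.

Measured in a functional assay on SK-OV-3 cells (Homo sapiens) for inhibition, read by sulforhodamine B assay, with a stated time of 48 h, tested at 10 uM; a higher number here means more inhibition of growth at the concentration tested, a lower number less inhibition of growth:
Compound 1 `CC(=O)c1ccc(NC(=O)Cn2nc(-c3ccc(Cl)cc3)nc2N)cc1`: 22%
Compound 2 `COc1ccc(-c2nc3sc(-c4ccccc4)cn3n2)cc1`: 32%
Compound 3 `Clc1ccc(-c2cn3nc(-c4ccccc4)nc3s2)cc1`: 64%

Of these three compounds, compound 3 gives the highest number, 64%. Among the compounds with values here, its gaps to compound 2 and to compound 1 both lie beyond the usual scatter of repeated measurements, so it is a clear front-runner in this assay, though only three compounds have been measured so far.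

The next compound, compound 4 `COc1ccc(-c2nc3sc(-c4ccc(Cl)cc4)cn3n2)cc1`, keeps the structure of compound 3 with one change: methoxy in place of hydrogen on an aromatic carbon. In words, methoxy takes the place of hydrogen on an aromatic carbon.

Within the data shown here, no two measured compounds differ in only one place, so the data do not show directly what this change does. The only hint is indirect. Compound 2 also carries methoxy and gives 32%, a lower number than that of compound 3. That comparison is weak, but it points downward, so a moderate fall is expected, and a result within the scatter would not be surprising. The expected change is a number 14 percentage points lower from compound 3 to compound 4 (beyond the scatter). For compound 4, the estimated value is 50%, with an expected range from 25% to 75%.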

Compound 4, percent growth inhibition at one concentration: 50.6%
For compound 4 the middle estimate is 0.6 percentage points below the measured one; the measured number falls inside the stated range.
By their numbers in this assay, from the lowest: compounds 1 and 2 (each within the scatter of the next); then compound 4; then compound 3.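

In this assay, within the data shown here, the first comparisons of compounds that differ in one place become available: methoxy in place of hydrogen on an aromatic carbon, para to a large group, gives a number 13.4 percentage points lower from compound 3 to compound 4 (beyond the scatter), so this position tolerates methoxy at a modest cost and much of the inhibition of growth remains. A second comparison concerns a different place, where chloro in place of hydrogen on an aromatic carbon gives a number 18.6 percentage points higher from compound 2 to compound 4 (beyond the scatter), so with methoxy present, chloro goes with a higher number, and the two changes pull in opposite directions across these three compounds. No measurement among these data explains why either step runs as it does.

Each change is seen only once, so the compounds shown leave open whether the effect of chloro holds without methoxy, and whether the effect of methoxy would be the same with a different group in the place of chloro. They also leave open how a smaller or very different group at the methoxy position, such as fluoro, an amine or a carboxylic acid, would compare with hydrogen and methoxy.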